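Halogen swap on the triazole aryl of a cytotoxic series

The compounds below may be only part of what the source reports. "The series", "measured", "known", "first", "only" and "open" are said of these compounds alone.

Three compounds of the series have been run in a functional assay on HL-60 cells (Homo sapiens) for cytotoxicity, read by MTT assay, with a stated time of 4 days; on this read-out higher numbers stand for weaker inhibition and lower numbers for stronger inhibition. Compound 1 `C=C1C[C@]23C[C@@]1(O)CC[C@@H]2c1cccc(C)c1[C@@H]3Cn1cc(-c2ccc(Br)cc2)nn1` carries a bromo on the aryl of the triazole; in this assay compound 1 returns only the assay limit, > 20000 nM. Compound 2 `C=C1C[C@]23C[C@@]1(O)CC[C@H]2c1ccc(O)c(C)c1[C@@H]3Cn1cc(-c2ccc(OC)cc2)nn1` likewise gives only a limit in this assay, > 20000 nM. Compound 3 `C=C1C[C@]23C[C@@]1(O)CC[C@H]2c1cc(Br)c(O)c(C)c1[C@@H]3Cn1cc(-c2ccccc2)nn1` also sits at a limit in this assay, > 20000 nM. Among the measured compounds shown here, compound 1 therefore stands nowhere in particular among the numbers: all three measured values are limits, (the limit of > 20000 nM in this assay, at which 3 of the 3 values shown sit), and no compound can be ranked against another. For the measured compounds named here, no step between two measured compounds that differ in a single place is available.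

Compound 4 `C=C1C[C@]23C[C@@]1(O)CC[C@@H]2c1cccc(C)c1[C@@H]3Cn1cc(-c2ccc(Cl)cc2)nn1` is the next one to measure. It differs from compound 1 in one place: chloro in place of bromo on an aromatic carbon. Going by the values given here, with every measured member at the limit, there is no measured step to lean on. The readout of compound 4 in this assay is expected to stay where compound 1 sits because the limit of > 20000 nM in this assay, at which 3 of the 3 values shown sit, shows the whole set at the limit. For compound 4 the expected step in this assay is a step that the limit leaves unreadable from compound 1 to compound 4, none beyond the scatter. Compound 4 is therefore expected at 30000 nM, within 10000 nM to 100000 nM, and most likely reported again only as a limit.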

Compound 4, half-maximal inhibitory concentration: > 20000 nM
Compound 4 ended at the assay's limit; the forecaster's own chance of this, stated with the estimate: 85%; the middle value is on the limit's open side.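

In this assay compound 4 gives > 20000 nM as a limit and not a number. No new step can be read between compound 1 and compound 4, which differ by chloro in place of bromo: the limit of > 20000 nM in this assay, at which 4 of the 4 values shown sit. The compounds shown leave open whether any member of the series has a measurable potency in this assay and whether chloro and bromo differ there.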